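Methoxy for Ethyl in a Cytotoxicity Series

The compounds below may be only part of what the source reports. "The series", "measured", "known", "first", "only" and "open" are said of these compounds alone.

Compound 1 `COc1ccc(-c2ccc(C(=O)Nc3ccc(Oc4ccnc5[nH]ccc45)cc3)nc2)cc1` gives > 10000 nM in a functional assay on MCF7 cells (Homo sapiens) for cytotoxicity, read by MTT assay, with a stated time of 72 h (a lower number here means a stronger inhibitor, a higher number a weaker inhibitor), which is a limit of the assay. Compound 2 `CCc1ccc(-c2ccc(C(=O)Nc3ccc(Oc4ccnc5[nH]ccc45)cc3)nc2)cc1` gives > 10000 nM in this assay, again a limit. Among the compounds with values here, compound 3 `CCc1ccc(-c2ccnc(C(=O)Nc3ccc(Oc4ccnc5[nH]ccc45)c(F)c3)c2)cc1` gives 7470 nM in this assay, the only number among the three.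

The change from compound 2 to compound 1 is methoxy in place of ethyl on an aromatic carbon, and the step that the two limits leave unreadable from compound 2 to compound 1 cannot be sized because both values sit at the limit of > 10000 nM in this assay, at which 2 of the 3 values shown sit. The difference between the cores of compound 2 and compound 3 is not broken down here. Compound 4 `COc1ccc(-c2ccnc(C(=O)Nc3ccc(Oc4ccnc5[nH]ccc45)c(F)c3)c2)cc1` carries the same change on the core of compound 3, (methoxy in place of ethyl on an aromatic carbon). Since the earlier step gave no readable size, only a small step of a 1.2-fold higher number from compound 3 to compound 4 (0.08 log units; within the scatter) is expected, and compound 4 is estimated at 9000 nM, between 4000 nM and 20000 nM, with a fair chance that only a limit is reported.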

Compound 4, half-maximal inhibitory concentration: 9110 nM
The estimate for compound 4 lay 1.0-fold (0.01 log units) below the measured number, within the range that was stated.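

On the second core, the change from 4-ethylphenyl to 4-methoxyphenyl gives a 1.2-fold higher number from compound 3 to compound 4 (0.09 log units; within the scatter) in this assay, so the two groups are not told apart on this core. The same change on the first core cannot be read, which leaves one sized step and no comparison of the change across the two cores: the limit of > 10000 nM in this assay, at which 2 of the 4 values shown sit.

A step within the scatter on one core also does not show how the change would behave on any other core. On these data alone, whether an amine, a carboxylic acid or a longer chain in place of ethyl or methoxy would give a step beyond the scatter stays open. Which part of the difference between the two cores bears on the values also stays open.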